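Swapping Carboxy for Cyano: What Cytotoxicity to Expect

The source may report more compounds than this note shows. Statements on the series, on what has been measured and on what is new or still open speak of the compounds shown alone.

Measured in an ADME assay on TZM cells (Homo sapiens) for cytotoxicity, read by XTT assay, with a stated time of 4 days; on this read-out lower numbers stand for higher toxicity in this test and higher numbers for lower toxicity in this test:
- compound 1 `C=CCc1cc(C)c(Oc2ccc(N)c(Nc3ccc(C#N)cc3)n2)c(C)c1`: 8460 nM
- compound 2 `Cc1cc(/C=C/C(=O)O)cc(C)c1Oc1ccc(N)c(Nc2ccc(C#N)cc2)n1`: 18000 nM

Of these two numbers, compound 2 holds the higher, at 18000 nM, which means the lower toxicity in this test. The next compound, compound 3 `Cc1cc(/C=C/C#N)cc(C)c1Oc1ccc(N)c(Nc2ccc(C#N)cc2)n1`, has cyano in place of carboxy on a double-bonded chain carbon bound to a double-bonded chain carbon. Put another way, 2-cyanoethenyl stands where compound 2 has 2-carboxyethenyl.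

Among the measured compounds shown here, only one measured step bears on this change: a 2.1-fold higher number from compound 1 to compound 2 (0.33 log units; beyond the scatter), with 2-carboxyethenyl in place of allyl on an aromatic carbon. That step is modest but beyond the scatter. Compound 3, like compound 1 at 8460 nM, carries no carboxy, so a move back toward the lower number seems the likelier direction. For the measured compounds named here, one step is thin evidence, however, and no measured compound yet carries the cyano group on this chain.

The expected change is a 2.1-fold lower number from compound 2 to compound 3 (0.33 log units; beyond the scatter) in this assay, again a modest step. For compound 3 the estimate is 8500 nM, with an expected range of 3000 nM to 20000 nM.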

Compound 3, half-maximal cytotoxic concentration: 9750 nM
For compound 3 the middle estimate is 1.1-fold (0.06 log units) below the measured one; measured number inside the range.
By their numbers in this assay, from the lowest: compounds 1, 3 and 2 (each within the scatter of the next, the first and the last beyond it).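

With cyano in place of carboxy on a double-bonded chain carbon bound to a double-bonded chain carbon, this assay gives a step that stays within the scatter (a 1.8-fold lower number from compound 2 to compound 3 (0.27 log units; within the scatter)), so this swap cannot be told apart from no change. The swap of the whole side chain gives the same kind of reading (a 1.2-fold higher number from compound 1 to compound 3 (0.06 log units; within the scatter)), which places compound 3 within the scatter of both earlier compounds, even though compound 1 and compound 2 lie beyond the scatter of each other. The earlier pair suggested that 2-carboxyethenyl in place of allyl gave a modest shift, but the new compound shows that a chain without carboxy need not be separable from either side, and nothing available explains these readings.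

The compounds shown leave open how a primary amide or a methyl ester at this same chain carbon would read on this scale, and whether either would fall outside the narrow band these three occupy. They also leave open whether the chain's double bond matters, which a saturated 2-cyanoethyl chain or a longer chain ending in cyano could begin to answer.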